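The compounds below may be only part of what the source reports. "The series", "measured", "known", "first", "only" and "open" are said of these compounds alone.

Series notes. Compound 1 `Oc1cccc(-c2cc(-c3ccc(F)cc3)cc(-c3cccc(O)c3)n2)c1` and compound 2 `Oc1ccc(-c2cc(-c3ccc(F)cc3)cc(-c3cccc(O)c3)n2)cc1` share one core and differ in a single aryl group. In a functional assay on HeLa cells (Homo sapiens) for inhibition (on this read-out higher numbers stand for weaker inhibition and lower numbers for stronger inhibition), compound 1 gives 1280 nM. In this assay, going by the values given here, compound 2 gives 8080 nM, the highest of the two numbers so far; the one measured step, a 6.3-fold higher number from compound 1 to compound 2 (0.80 log units; beyond the scatter), is the only comparison available. Compound 3 `Oc1ccc(-c2cc(-c3cccc(C(F)(F)F)c3)cc(-c3cccc(O)c3)n2)cc1` is unmeasured. It keeps the 3-hydroxyphenyl and 4-hydroxyphenyl groups of compound 2 and alters the third aryl group: 3-(trifluoromethyl)phenyl in place of 4-fluorophenyl on an aromatic carbon, at a carbon of the shared core opposite the ring nitrogen. Among the compounds with values here, no measured step touches this position; the step from compound 1 to compound 2 concerns a hydroxyphenyl group and does not bear on an exchange of 4-fluorophenyl for 3-(trifluoromethyl)phenyl, so it offers no direction. With nothing to anchor a shift, the expected step in this assay is none beyond the scatter, and compound 3 is expected to land near compound 2: a 1.0-fold lower number from compound 2 to compound 3 (0.00 log units; within the scatter). Compound 3 in this assay is therefore estimated at 8000 nM, with a range from 2500 nM to 25000 nM that reflects the lack of any comparable step in the series.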

Compound 3, half-maximal inhibitory concentration: 16200 nM
For compound 3 the middle estimate is 2.0-fold (0.31 log units) below the measured one, within the range that was stated.
By their numbers in this assay, from the lowest: compound 1; then compounds 2 and 3 (each within the scatter of the next).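

Going by these compounds alone, compound 2 and compound 3 give the first measured exchange at the aromatic carbon opposite the ring nitrogen: in this assay, 3-(trifluoromethyl)phenyl in place of 4-fluorophenyl gives a 2.0-fold higher number from compound 2 to compound 3 (0.30 log units; within the scatter), so the two compounds cannot be told apart on this read-out. Within the data shown here, at this position, therefore, an aryl group of 10 heavy atoms carrying trifluoromethyl reads the same as one of 7 heavy atoms carrying fluorine, at least with the 3-hydroxyphenyl and 4-hydroxyphenyl groups of compound 2 in place, while the only step so far beyond the scatter remains the hydroxyphenyl exchange, a 6.3-fold higher number from compound 1 to compound 2 (0.80 log units; beyond the scatter). No measurement at hand offers an account of this result.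

The compounds shown leave open whether the same exchange would also read within the scatter on the two 3-hydroxyphenyl groups of compound 1, and whether the trifluoromethyl group and its ring position count separately, since both differ at once between compound 2 and compound 3. Also open, from the compounds shown here alone, is how a phenyl ring bearing an amine or a carboxylic acid would read at this carbon in this assay.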